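Methoxy for Methyl on the Aryl Ring

A few compounds are considered here, and "the series" means these few. Any claim that something is new, unique, unknown or untested is made for them only; others in the source may bear on it.

For the measured compounds named here, in an assay on isolated protein for binding affinity to melanin-concentrating hormone receptor 1 (Homo sapiens) (on this read-out higher numbers stand for weaker inhibition and lower numbers for stronger inhibition), compound 3 `Cc1ccc(-c2cc3ncn([C@H]4CCN(C(=O)N(C)[C@H]5CCN(C6CCOCC6)C5)C4)c(=O)c3s2)c(C)c1` gives 70 nM, the highest of the three numbers measured so far. Compound 2 `Cc1ccc(-c2cc3ncn([C@H]4CCN(C(=O)N(C)[C@H]5CCN(C)C5)C4)c(=O)c3s2)c(C)c1` gives 49 nM, and the step of a 1.4-fold higher number from compound 2 to compound 3 (0.15 log units; within the scatter) lies within the scatter. Compound 1 `CN(C(=O)N1CC[C@H](n2cnc3cc(-c4ccc(Cl)cc4)sc3c2=O)C1)[C@H]1CCN(C2CCC2)C1`, built on a different aryl ring and amine substituent, gives 1 nM, a far lower number. Compound 4 `COc1ccc(-c2cc3ncn([C@H]4CCN(C(=O)N(C)[C@H]5CCN(C6CCOCC6)C5)C4)c(=O)c3s2)c(C)c1` differs from compound 3 by methoxy in place of methyl on an aromatic carbon. Going by the values given here, no measured step alters this aryl ring; the one measured step changes only the amine substituent, so nothing directly bears on this exchange. The expected step is therefore none beyond the scatter, which for compound 4 means an estimated 1.2-fold lower number from compound 3 to compound 4 (0.07 log units; within the scatter). Compound 4 is thus expected to give about 60 nM, with a range from 20 nM to 200 nM.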

Compound 4, inhibition constant: 28 nM
Beside the measured number, compound 4's estimate is 2.1-fold (0.33 log units) above it; the range from low to high includes it.
By their numbers in this assay, from the lowest: compound 1; then compounds 4, 2 and 3 (each within the scatter of the next, the first and the last beyond it).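

For the compounds shown here, this is the first measured change on the aryl ring: in this assay methoxy in place of methyl, para to the large group, gives a 2.5-fold lower number from compound 3 to compound 4 (0.40 log units; beyond the scatter) and so a modest step beyond the scatter. Going by these compounds alone, the one earlier step, on the amine substituent, stayed within the scatter, so this aryl position shows an effect that step did not. Nothing measured here explains why the number falls.

Going by these compounds, whether a longer chain such as ethoxy, or a hydroxyl, at this place would lower the number further remains open. So does whether methoxy would give a similar step on compound 2, which carries methyl on the amine nitrogen.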